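A few compounds are considered here, and "the series" means these few. Any claim that something is new, unique, unknown or untested is made for them only; others in the source may bear on it.

Compound 1 `CCn1cc(-c2ccc(Cl)cc2)c(=O)c2cc(F)c(N3CCNCC3)cc21` gives 1250 nM in a functional assay on A549 cells (Homo sapiens) for antiproliferative activity, read by MTT assay, with a stated time of 48 h; on this read-out lower numbers stand for stronger inhibition and higher numbers for weaker inhibition.
Compound 2 `CCn1cc(-c2ccc(C#N)cc2)c(=O)c2cc(F)c(N3CCNCC3)cc21` gives 1090 nM in this assay.

Compound 1 stands at the higher of the two measured numbers, yet the step of a 1.1-fold lower number from compound 1 to compound 2 (0.06 log units; within the scatter) is within the scatter, so the two cannot be told apart. Compound 3 `CCn1cc(-c2cccc(OC)c2)c(=O)c2cc(F)c(N3CCNCC3)cc21` is unmeasured; it differs from compound 1 by 3-methoxyphenyl in place of 4-chlorophenyl on an aromatic carbon. For the measured compounds named here, the single measured step concerns a different change and is within the scatter, so no step beyond the scatter is expected in this assay. Compound 3 is therefore estimated at 1400 nM, ranging from 500 nM to 4000 nM. This estimate means an expected step of a 1.1-fold higher number from compound 1 to compound 3 (0.05 log units; within the scatter).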

Compound 3, half-maximal inhibitory concentration: 800 nM
Compound 3: the middle estimate sits 1.8-fold (0.24 log units) above what was measured; the range from low to high includes it.
By their numbers in this assay, from the lowest: compounds 3, 2 and 1 (each within the scatter of the next).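

Placing 3-methoxyphenyl on this aromatic carbon gives a 1.6-fold lower number from compound 1 to compound 3 (0.19 log units; within the scatter) and a 1.4-fold lower number from compound 2 to compound 3 (0.13 log units; within the scatter) in this assay. So this position accepts a 3-methoxyphenyl, with its one hydrogen-bond acceptor, in place of the 4-chlorophenyl, with none, and the number stays within the scatter, a wider change than the earlier swap of chloro for cyano. No further measurement bears on this result. Still open, from the compounds shown here alone, is whether an amine or a carboxylic acid on this phenyl ring, or a longer chain at this position, would produce a step beyond the scatter.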